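Dropping the Acylurea and Keeping a Chlorine on the Chain

The compounds below may be only part of what the source reports. "The series", "measured", "known", "first", "only" and "open" are said of these compounds alone.

Three compounds built on one shared core have been examined in a functional assay on HT-29 cells (Homo sapiens) for antiproliferative activity, with a stated time of 48 h; on this read-out lower numbers stand for stronger inhibition and higher numbers for weaker inhibition. Compound 1 `CCCCC(O)c1cccc(NC(=O)NCCCCl)c1` carries a 3-chloropropyl group on the urea nitrogen; in this assay compound 1 gives 19000 nM. Compound 2 `CCCCC(O)c1cccc(NC(=O)NC(=O)CCl)c1` carries a (chloromethyl)carbonyl group in that position, and compound 2 gives 10000 nM; the change is a 1.9-fold lower number from compound 1 to compound 2 (0.28 log units; within the scatter). Compound 3 `CCCCC(O)c1cccc(NC(=O)NC(=O)CC)c1` bears a propanoyl group instead. For compound 3 this assay reports only a limit, > 100000 nM. That value is the limit of > 100000 nM in this assay, at which 1 of the 3 values shown sits. Compound 3 therefore stands at the weak end of the numbers shown: an at least 5.2-fold higher number from compound 1 to compound 3 (0.72 log units; beyond the scatter), and an at least 10-fold higher number from compound 2 to compound 3 (1.00 log units; beyond the scatter).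

Compound 4 `CCCCC(O)c1cccc(NC(=O)CCCl)c1` has not yet been measured. It differs from compound 3 by 2-chloroethyl in place of propanoylamino on a carbonyl carbon, so the urea is gone and the acyl chain again carries a chlorine. Going by the values given here, the steps that bear on this are the two in which a chlorine was lost, an at least 5.2-fold higher number from compound 1 to compound 3 (0.72 log units; beyond the scatter) and an at least 10-fold higher number from compound 2 to compound 3 (1.00 log units; beyond the scatter), both beyond the scatter; compound 4 brings a chlorine back onto a saturated chain, as compound 1 and compound 2 have. The expected step is therefore an at least 4.0-fold lower number from compound 3 to compound 4 (0.60 log units; beyond the scatter), back toward the numbers of compound 1 and compound 2. Compound 4 is estimated at 25000 nM, between 6000 nM and 100000 nM.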

Compound 4, half-maximal inhibitory concentration: > 100000 nM
Compound 4: a limit, no number; the forecaster's own chance of this, stated with the estimate: 25%; at least 4.0-fold (0.60 log units) between middle value and limit.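

A chlorine on a saturated chain is not enough on its own to give a measurable number: in this assay compound 4 keeps such a chlorine, yet for compound 4 only a limit is reported, > 100000 nM. Replacing the nitrogen-bearing groups on this carbonyl carbon with 2-chloroethyl gives an at least 10-fold higher number from compound 2 to compound 4 (1.00 log units; beyond the scatter) and an at least 5.2-fold higher number from compound 1 to compound 4 (0.72 log units; beyond the scatter), so at this position the activity seen on this read-out goes with the urea and chlorine together, not with the chlorine alone. The step between compound 3 and compound 4 cannot be read, and both compounds rest at the same limit of the assay: the limit of > 100000 nM in this assay, at which 2 of the 4 values shown sit.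

Going by these compounds, how far compound 3 and compound 4 lie past that limit stays unknown, and so does whether the propanoyl and 2-chloroethyl chains differ at all on this read-out. On these data alone, it also remains open whether a longer chain ending in chlorine on this carbonyl carbon, or a urea nitrogen bearing a chloroacetyl group with a different core substituent such as an amine, would restore a measurable number.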